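This account rests on a few compounds, and the source may have more. Where it says the series, first, only, none or still open, it means among the compounds named here.

Measured compounds:
Compound 1 `COc1ccc(/C=C/C(=O)c2cc(-c3ccc(OC)c(OC)c3)n3nc(-c4ccccc4)cc3n2)cc1` gives 22000 nM in a functional assay on MDA-MB-231 cells (Homo sapiens) for antiproliferative activity, read by MTT assay, with a stated time of 24 h; a lower number here means a stronger inhibitor, a higher number a weaker inhibitor.
Compound 2 `COc1cc(-c2cc(/C=C/C(=O)c3ccccc3)nc3cc(-c4ccccc4)nn23)cc(OC)c1OC` gives 15800 nM in this assay.

For the measured compounds named here, compound 2 is one of only two compounds with a number in this assay, and its value sits within the usual scatter of the value for compound 1, so neither of the two can be set apart from the other on these data. Compound 3 `COc1ccc(/C=C/C(=O)c2cc(-c3cc(OC)c(OC)c(OC)c3)n3nc(-c4ccccc4)cc3n2)cc1` has not yet been measured. It differs from compound 2 in one place: (2-(4-methoxyphenyl)ethenyl)carbonyl in place of 2-benzoylethenyl on an aromatic carbon. Going by the values given here, no measured pair shows the effect of this change on its own, so there is no step from which to read its size. Given that compound 1, which also carries the (2-(4-methoxyphenyl)ethenyl)carbonyl group, gives 22000 nM, the change is expected to leave the number much where it is, with no step beyond the scatter. Compound 3 is therefore estimated at 18000 nM, with a range from 7000 nM to 45000 nM, which would mean a step of a 1.1-fold higher number from compound 2 to compound 3 (0.06 log units; within the scatter).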

Compound 3, half-maximal inhibitory concentration: 16500 nM
Compound 3: the middle estimate sits 1.1-fold (0.04 log units) above what was measured; the range from low to high includes it.
By their numbers in this assay, from the lowest: compounds 2, 3 and 1 (each within the scatter of the next).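

In this assay, (2-(4-methoxyphenyl)ethenyl)carbonyl in place of 2-benzoylethenyl on this aromatic carbon gives a 1.0-fold higher number from compound 2 to compound 3 (0.02 log units; within the scatter), so the exchange of these two groups at this position leaves the value within the scatter. The second pair concerns a different place: methoxy in place of hydrogen on an aromatic carbon gives a 1.3-fold lower number from compound 1 to compound 3 (0.12 log units; within the scatter), which also lies within the scatter, so neither change sets one compound apart from another. No measurement is available that would explain these results.

The compounds shown leave open whether this position would respond to a group of another kind, such as an amine or a carboxylic acid, in place of (2-(4-methoxyphenyl)ethenyl)carbonyl. They also leave open whether any single change to the shared core can give a step beyond the scatter.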